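Sulfonamide Nitrogen Substituent Swap in a Hydroxamic Acid Series

The compounds below may be only part of what the source reports. "The series", "measured", "known", "first", "only" and "open" are said of these compounds alone.

Measured compounds in an assay on Sf9 cells for inhibition of histone deacetylase 11 (Homo sapiens), read by fluorescence and mobility shift assay; on this read-out higher numbers stand for weaker inhibition and lower numbers for stronger inhibition:
Compound 1 `CC(C)N(Cc1ccc(C(=O)NO)cc1)Cc1cc(F)c(F)c(F)c1F` gives > 1000 nM, a limit of the assay.
Compound 2 `CC(C)N(Cc1ccc(C(=O)NO)cn1)S(=O)(=O)c1cc(F)c(F)c(F)c1F` gives > 1000 nM, a limit of the assay.
Compound 3 `COCCN(Cc1ccc(C(=O)NO)cc1)S(=O)(=O)c1cc(F)c(F)c(F)c1F` gives > 1000 nM, a limit of the assay.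

Compound 3 therefore stands at the limit, and so do the other two compounds shown (the limit of > 1000 nM in this assay, at which 3 of the 3 values shown sit); none of the three yields a number within the measured range. Compound 4 `CC(C)N(Cc1ccc(C(=O)NO)cc1)S(=O)(=O)c1cc(F)c(F)c(F)c1F` differs from compound 3 in a single place: isopropyl in place of 2-methoxyethyl on a sulfonamide nitrogen. Within the data shown here, no step between measured compounds exists here, so the size of this change cannot be read from the data. The expected step is a step that the limit leaves unreadable from compound 3 to compound 4, within the usual scatter. Compound 4 is accordingly estimated at 3000 nM, in a range from 800 nM to 20000 nM, and is expected to be reported again only as a limit.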

Compound 4, half-maximal inhibitory concentration: > 1000 nM
Compound 4 ended at the assay's limit; the forecaster's own chance of this, stated with the estimate: 85%; the middle value lies beyond the limit too.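

No step can be read from compound 3 to compound 4, because both values are limits: the limit of > 1000 nM in this assay, at which 4 of the 4 values shown sit.

The compounds shown leave open how strongly any of them inhibits, and whether isopropyl and 2-methoxyethyl on a sulfonamide nitrogen differ at all.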